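Isobutyl to isopropyl on the shared core

The compounds below may be only part of what the source reports. "The series", "measured", "known", "first", "only" and "open" are said of these compounds alone.

Values from a physicochemical assay for lipophilicity, using the shake flask method, measured as octanol-water partition, at pH 7.4 (a lower number here means a more polar compound, a higher number a more lipophilic compound), for the three measured compounds
Compound 1 `CC(C)n1cc(-c2ccnc3[nH]c(C4CCNCC4)cc23)ccc1=O` gives -0.2 here
Compound 2 `CC(C)n1cc(-c2ccnc3[nH]c(C4CCN(CC(=O)N(C)C)CC4)cc23)cnc1=O` gives 0.4 here
Compound 3 `CC(C)Cn1cc(-c2ccnc3[nH]c(C4CCN(CC(=O)N(C)C)CC4)cc23)ccc1=O` gives 2 here

Compound 3 at 2 stands highest of the three measured compounds, and its value lies beyond the scatter from both of the others. Compound 4 `CC(C)n1cc(-c2ccnc3[nH]c(C4CCN(CC(=O)N(C)C)CC4)cc23)ccc1=O` has not yet been measured. It differs from compound 3 in one place only, with isopropyl in place of isobutyl on an aromatic nitrogen of a six-membered aromatic ring with 1 nitrogen. Among the measured compounds shown here, no two measured compounds differ in one place alone, so the data offer no direct precedent for this change. Compound 1 and compound 2 also carry isopropyl, but each differs from compound 4 elsewhere as well, so their values cannot size the step. A small fall is expected, and the estimated step of a number 0.40 log units lower from compound 3 to compound 4 (beyond the scatter) lies only just beyond the scatter. The estimate for compound 4 is 1.6 with an expected range from 1.2 to 1.9 in the measurement to come.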

Compound 4, distribution coefficient: 1.9
For compound 4 the middle estimate is 0.30 log units below the measured one; low and high end bracket the measured number.
By their numbers in this assay, from the lowest: compound 1; then compound 2; then compounds 4 and 3 (each within the scatter of the next).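

In this assay, isopropyl in place of isobutyl on an aromatic nitrogen gives a number 0.10 log units lower from compound 3 to compound 4 (within the scatter) and so leaves the number at this position essentially unmoved across these two alkyl groups. Compound 4 also opens one-place comparisons at two other sites: the group on the aromatic carbon with a ring of 1 nitrogen, in place of a ring of 2 hetero atoms, gives a number 1.50 log units higher from compound 2 to compound 4 (beyond the scatter) and (dimethylcarbamoyl)methyl in place of hydrogen on the amine nitrogen in a ring gives a number 2.10 log units higher from compound 1 to compound 4 (beyond the scatter) as the two large steps in the set. No measurement here accounts for the size of any of these steps.

The compounds shown leave open whether a methyl group or a longer chain on that aromatic nitrogen would stay as close to compound 4. They also leave open what a carboxylic acid on the amine nitrogen would do.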